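A few compounds are considered here, and "the series" means these few. Any claim that something is new, unique, unknown or untested is made for them only; others in the source may bear on it.

Compound 1 `COc1ccc(-c2nsc3c2NC(=O)CC3c2cccc(OC)c2)cc1` gives 282 nM in a functional assay on MDA-MB-435 cells (Homo sapiens) for antiproliferative activity, read by sulforhodamine B assay, with a stated time of 48 h; on this read-out lower numbers stand for stronger inhibition and higher numbers for weaker inhibition. Compound 2 `COc1ccc(-c2nsc3c2NC(=O)CC3c2cccc(Cl)c2)cc1` gives 749 nM in this assay. The two differ only by chloro in place of methoxy on an aromatic carbon, and that change made a step of a 2.7-fold higher number from compound 1 to compound 2 (0.42 log units; beyond the scatter). Compound 3 `COc1ccc(-c2nsc3c2NC(=O)CC3c2ccsc2)cc1` carries a different group on the shared core; how it differs from compound 1 is thiophen-3-yl in place of 3-methoxyphenyl on a saturated ring carbon. In this assay compound 3 gives 23.5 nM, which is a step of a 12-fold lower number from compound 1 to compound 3 (1.08 log units; beyond the scatter) and a step of a 32-fold lower number from compound 2 to compound 3 (1.50 log units; beyond the scatter); among these three compounds it has the lowest number, and both steps to it lie beyond the scatter.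

Compound 4 `O=C1CC(c2ccsc2)c2snc(-c3ccc(Cl)cc3)c2N1` has not yet been measured in this assay. It differs from compound 3 by chloro in place of methoxy on an aromatic carbon. For the measured compounds named here, this is the same kind of change as the one from compound 1 to compound 2, not the same: there the place was meta to a large group, here it is para to a large group, on a different ring of the shared core. Going by the values given here, the only guide is the step from compound 1 to compound 2, which was a 2.7-fold higher number from compound 1 to compound 2 (0.42 log units; beyond the scatter), and the starting point is the measured number of compound 3, 23.5 nM. The step from compound 3 to compound 4 is therefore expected to be about a 2.6-fold higher number from compound 3 to compound 4 (0.41 log units; beyond the scatter), though the changed place leaves the direction less certain. Compound 4 is expected to give about 60 nM in this assay, estimated between 22 nM and 170 nM.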

Compound 4, half-maximal inhibitory concentration: 260 nM
The estimate for compound 4 lay 4.3-fold (0.64 log units) below the measured number; the whole stated range lies below it.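

In this assay, chloro in place of methoxy gave a higher number in both cases shown, and with compound 3 as the starting point it made a step of an 11-fold higher number from compound 3 to compound 4 (1.04 log units; beyond the scatter). The direction of the change therefore held in both cases, but its size did not carry over from one core to the other: the same change on two cores in this assay, a 2.7-fold higher number (0.42 log units; beyond the scatter) from compound 1 to compound 2 and an 11-fold higher number (1.04 log units; beyond the scatter) from compound 3 to compound 4, 4.2-fold (0.62 log units) apart, beyond the scatter of two such steps This does not show what sets the size of the step, since the two cases differ in the place of the change as well as in the rest of the structure, and with only two cases the contribution of the place, here para to a large group, cannot be separated from that of the other differences.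

The compounds shown leave open how other groups at this para place, such as fluoro, hydroxy, an amine or a longer chain such as ethoxy, would compare with methoxy and chloro. They also leave open whether the same change would give a step of similar size with another ring on the saturated ring carbon, such as thiophen-2-yl or furan-3-yl, in place of thiophen-3-yl.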